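Dimethoxyphenyl swap carried onto the hydroxy core

The source may report more compounds than this note shows. Statements on the series, on what has been measured and on what is new or still open speak of the compounds shown alone.

Compound 1 `Clc1cccc(-c2ccc(-c3ccc(-c4nc5ccccc5[nH]4)cc3)cc2)c1` is the reference point; in a functional assay on DWD cells (Homo sapiens) for inhibition, read by sulforhodamine B assay (on this read-out lower numbers stand for stronger inhibition of growth and higher numbers for weaker inhibition of growth), compound 1 gives 100000 nM. Compound 2 `COc1ccc(-c2ccc(-c3ccc(-c4nc5ccccc5[nH]4)cc3)cc2)cc1OC` differs from it by 3,4-dimethoxyphenyl in place of 3-chlorophenyl on an aromatic carbon and in this assay compound 2 gives 42100 nM, so the step is a 2.4-fold lower number from compound 1 to compound 2 (0.38 log units; beyond the scatter). Compound 3 `Oc1cccc2[nH]c(-c3ccc(-c4ccc(-c5cccc(Cl)c5)cc4)cc3)nc12` keeps the 3-chlorophenyl end but carries the core change (hydroxy in place of hydrogen on an aromatic carbon); in this assay compound 3 gives 2100 nM, and the step is a 48-fold lower number from compound 1 to compound 3 (1.68 log units; beyond the scatter). Compound 3 thus has the lowest number of the three measured, both steps to it lying beyond the scatter.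

Compound 4 `COc1ccc(-c2ccc(-c3ccc(-c4nc5c(O)cccc5[nH]4)cc3)cc2)cc1OC` is not yet measured. It differs from compound 3 by 3,4-dimethoxyphenyl in place of 3-chlorophenyl on an aromatic carbon, and the place lines of the two changes read the same word for word, so this is the same change already seen on the core of compound 1. Among the measured compounds shown here, for this assay a step of a 2.3-fold lower number from compound 3 to compound 4 (0.37 log units; beyond the scatter) is expected, modest because the only precedent for the change is a 2.4-fold lower number from compound 1 to compound 2 (0.38 log units; beyond the scatter). For the measured compounds named here, no second example shows whether the core of compound 3 answers differently. The estimate for compound 4 is 900 nM, expected within 350 nM to 2500 nM.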

Compound 4, concentration for 50% growth inhibition: 1400 nM
Compound 4: the middle estimate sits 1.6-fold (0.19 log units) below what was measured; the range from low to high includes it.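

In this assay, the swap to 3,4-dimethoxyphenyl on the hydroxy core gives a 1.5-fold lower number from compound 3 to compound 4 (0.18 log units; within the scatter), and the step does not differ between the two cores: the same change on two cores in this assay, a 2.4-fold lower number (0.38 log units; beyond the scatter) from compound 1 to compound 2 and a 1.5-fold lower number (0.18 log units; within the scatter) from compound 3 to compound 4, 1.6-fold (0.20 log units) apart, within the scatter of two such steps The hydroxy change also carries over from the 3-chlorophenyl end to the 3,4-dimethoxyphenyl end, where it gives a 30-fold lower number from compound 2 to compound 4 (1.48 log units; beyond the scatter), and the two steps again agree: the same change on two cores in this assay, a 48-fold lower number (1.68 log units; beyond the scatter) from compound 1 to compound 3 and a 30-fold lower number (1.48 log units; beyond the scatter) from compound 2 to compound 4, 1.6-fold (0.20 log units) apart, within the scatter of two such steps This shows that the two changes behave independently within this set of four compounds and that the hydroxy change accounts for the large steps, but it rests on a single pair of steps for each change and cannot be extended to other end groups or cores.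

From the compounds shown here alone, it remains open whether an amine or a carboxylic acid in place of the hydroxy would keep a step of this size. Going by these compounds, it is also open whether a longer chain or an amine-bearing group in place of 3,4-dimethoxyphenyl would leave the hydroxy step unchanged.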